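This account rests on a few compounds, and the source may have more. Where it says the series, first, only, none or still open, it means among the compounds named here.

Measured so far:
compound 1 `Cc1ccc(-c2csc(NC(=O)COc3ccc(Br)cc3)n2)cc1` — 39100 nM
compound 2 `O=C(COc1ccc(Br)cc1)Nc1nc(-c2ccc(Cl)cc2)cs1` — 52400 nM
compound 3 `Cc1ccc(OCC(=O)Nc2nc(-c3ccc(C)cc3)cs2)cc1` — 41300 nM

These three compounds were tested in a functional assay on MCF7 cells (Homo sapiens) for cytotoxicity, read by MTT assay, with a stated time of 48 h; on this read-out lower numbers stand for stronger inhibition and higher numbers for weaker inhibition. Going by the values given here, all three values lie close together: the step of a 1.3-fold higher number from compound 1 to compound 2 (0.13 log units; within the scatter) and the step of a 1.1-fold higher number from compound 1 to compound 3 (0.02 log units; within the scatter) are both within the scatter, so no compound can be set apart from the others.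

Compound 4 `Cc1ccc(-c2csc(NC(=O)COc3ccc(Cl)cc3)n2)cc1` has not yet been measured. It differs from compound 3 by chloro in place of methyl on an aromatic carbon. The same change, seen once before, carries compound 1 into compound 2, namely (chloro in place of methyl on an aromatic carbon), and there it made the step of a 1.3-fold higher number from compound 1 to compound 2 (0.13 log units; within the scatter). The two cores on which the change is made differ in turn by methyl in place of bromo on an aromatic carbon; the place of the change reads the same in both cases.

For compound 4 in this assay the expected step is a 1.1-fold higher number from compound 3 to compound 4 (0.06 log units; within the scatter), a step of about the same size as before, because a 1.3-fold higher number from compound 1 to compound 2 (0.13 log units; within the scatter) stayed within the scatter. Compound 4 is therefore estimated at 47000 nM, with a likely range from 24000 nM to 92000 nM.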

Compound 4, half-maximal inhibitory concentration: 43800 nM
Beside the measured number, compound 4's estimate is 1.1-fold (0.03 log units) above it; the range from low to high includes it.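

In this assay, chloro in place of methyl gives a 1.1-fold higher number from compound 3 to compound 4 (0.03 log units; within the scatter), and chloro in place of bromo gives a 1.1-fold higher number from compound 1 to compound 4 (0.05 log units; within the scatter), so compound 4 cannot be set apart from compound 1 or compound 3. Set beside the earlier case, the same change behaves alike on the two cores: the same change on two cores in this assay, a 1.3-fold higher number (0.13 log units; within the scatter) from compound 1 to compound 2 and a 1.1-fold higher number (0.03 log units; within the scatter) from compound 3 to compound 4, 1.3-fold (0.10 log units) apart, within the scatter of two such steps. Going by these compounds alone, this agreement shows only that the change left the number within the scatter in both cases; it does not show that a change with a large effect would carry from one core to another, and two pairs cannot establish a rule for the series.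

The compounds shown carry only methyl, chloro and bromo at this place on the ring, so it stays open whether an amine, a carboxylic acid or a longer alkyl chain there would move the number beyond the scatter. Going by these compounds, it also stays open whether such a step would then be the same size on both cores.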